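This account rests on a few compounds, and the source may have more. Where it says the series, first, only, none or still open, it means among the compounds named here.

Measured compounds:
- compound 2, `CCOC(=O)c1cccc(NC(=O)Nc2cc(Oc3ccc4nc(NC(=O)C5CC5)sc4c3)ccc2F)c1`: 72 nM
- compound 1, `O=C(CCc1cccc(C(F)(F)F)c1)Nc1cc(Oc2ccc3nc(NC(=O)C4CC4)sc3c2)ccc1F`: 790 nM

Of the two compounds measured in an assay for binding affinity to receptor-interacting serine/threonine-protein kinase 3 (Homo sapiens), read by KINOMEscan and polymerase chain reaction, with a stated time of 1 h (a lower number here means tighter binding, a higher number weaker binding), compound 2 gives the lowest number, 72 nM, and compound 1 gives 790 nM. Within the data shown here, the single step between them, an 11-fold lower number from compound 1 to compound 2 (1.04 log units; beyond the scatter), replaces the whole side chain on the carbonyl carbon, so it speaks only loosely to the next change. Compound 3, `O=C(Nc1cccc(Br)c1)Nc1cc(Oc2ccc3nc(NC(=O)C4CC4)sc3c2)ccc1F`, keeps the urea of compound 2 and differs only by bromo in place of ethoxycarbonyl on an aromatic carbon. Among the measured compounds shown here, no measured step isolates a change of that kind, so the expectation rests on compound 2 alone, and a small step, within or close to the scatter, is expected as a 1.7-fold higher number from compound 2 to compound 3 (0.22 log units; within the scatter). Compound 3 is therefore expected to give about 120 nM in this assay, with a range from 35 nM to 400 nM.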

Compound 3, dissociation constant: 81 nM
For compound 3 the middle estimate is 1.5-fold (0.17 log units) above the measured one; the measured number falls inside the stated range.
By their numbers in this assay, from the lowest: compounds 2 and 3 (each within the scatter of the next); then compound 1.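

In this assay, the step of a 1.1-fold higher number from compound 2 to compound 3 (0.05 log units; within the scatter) shows that on this aromatic carbon, meta to a large group, ethoxycarbonyl with its 5 heavy atoms and 2 hydrogen-bond acceptors can give way to the single atom of bromo with no change beyond the scatter. The step of a 9.8-fold lower number from compound 1 to compound 3 (0.99 log units; beyond the scatter) then shows that the gap to compound 1 does not belong to the ester-bearing compound alone, since a second group on this ring keeps it. Nothing at hand explains why these two groups read alike. The compounds shown leave open how a carboxylic acid, an amine or a plain hydrogen would read on this carbon. They also leave open whether a longer chain than ethoxycarbonyl would still fit this pattern.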